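Moving the methoxy group around the phenyl ring

The compounds below may be only part of what the source reports. "The series", "measured", "known", "first", "only" and "open" are said of these compounds alone.

Measured so far:
- compound 1, `COc1ccc(-c2cc(COC(Cc3cn(C4CCN(Cc5ccc([N+](=O)[O-])cc5)CC4)nn3)c3ccc(Br)cc3)on2)cc1`: > 25000 nM
- compound 2, `COc1cccc(-c2cc(COC(Cc3cn(C4CCN(Cc5ccc([N+](=O)[O-])cc5)CC4)nn3)c3ccc(Br)cc3)on2)c1`: > 25000 nM
- compound 3, `O=[N+]([O-])c1ccc(CN2CCC(n3cc(CC(OCc4cc(-c5ccccc5F)no4)c4ccc(Br)cc4)nn3)CC2)cc1`: 9000 nM

In a functional assay on HCT-116 cells (Homo sapiens) for cytotoxicity, with a stated time of 48 h (a higher number here means a weaker inhibitor, a lower number a stronger inhibitor), compound 1 gives > 25000 nM, which is a limit of the assay and not a number. Compound 2 likewise reaches only a limit, > 25000 nM. For the measured compounds named here, compound 3 is the one member of this set with a measured number, 9000 nM. Two of the three values sit at the limit of > 25000 nM in this assay, at which 2 of the 3 values shown sit, so the steps starting from compound 1 or compound 2 can only be read partly: a step that the two limits leave unreadable from compound 1 to compound 2; an at least 2.7-fold lower number from compound 1 to compound 3 (0.44 log units; beyond the scatter); an at least 2.7-fold lower number from compound 2 to compound 3 (0.44 log units; beyond the scatter).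

Compound 4, `COc1ccccc1-c1cc(COC(Cc2cn(C3CCN(Cc4ccc([N+](=O)[O-])cc4)CC3)nn2)c2ccc(Br)cc2)on1`, has not yet been measured. It differs from compound 1 by 2-methoxyphenyl in place of 4-methoxyphenyl on an aromatic carbon. Of the measured steps, the move from 4-methoxyphenyl to 3-methoxyphenyl says nothing readable, while the move to 2-fluorophenyl gave at least a modest gain. Compound 4 keeps the methoxy group but shifts it, so a weak compound is expected, with a fair chance that this assay again reports only a limit. The estimate for compound 4 is 18000 nM, between 7000 nM and 50000 nM, meaning an expected step of an at least 1.3-fold lower number from compound 1 to compound 4 (0.14 log units; that floor lies within the scatter).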

Compound 4, half-maximal inhibitory concentration: > 25000 nM
Compound 4: a limit, no number; the forecaster's own chance of this, stated with the estimate: 55%; middle value at least 1.3-fold (0.14 log units) away from the limit.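

With compound 4, the methoxy group has been shown as 2-methoxyphenyl, 3-methoxyphenyl and 4-methoxyphenyl, and none of the three gives a measured number in this assay: the limit of > 25000 nM in this assay, at which 3 of the 4 values shown sit.

The steps among compound 1, compound 2 and compound 4 therefore cannot be read, and these three cannot be ranked against one another. For the compounds shown here, the earlier steps to compound 3 changed both the group and its place on the phenyl ring, whereas compound 4 offers the first comparison with the place held fixed: methoxy in place of fluoro gives an at least 2.7-fold higher number from compound 3 to compound 4 (0.44 log units; beyond the scatter). The better result for compound 3 in this set therefore cannot be credited to the substituent's place on the ring alone, since the same place carrying methoxy still ends at the limit.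

On these data alone, it remains open whether fluoro itself matters or whether removing methoxy would be enough, a question that a plain unsubstituted phenyl ring would address. A chloro group or an amine at the same place, and fluoro at the other two places on the ring, are also not covered by the compounds shown.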